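Swapping a Five-Membered Ring at One Aromatic Position

The source may hold more compounds than are shown below. What is called first, only, known or untested is meant among the compounds shown, and "the series" means these compounds.

Compound 1, `CCC(C)(C)Cc1c[nH]c(CCc2ccc(-c3cccc(N)n3)cc2)n1`, gives 119 nM in a functional assay on HEK293 cells for agonist activity at Bombesin receptor subtype-3 (Mus musculus), read by luminescence and calcium flux, with a stated time of 10 min; on this read-out higher numbers stand for an effect only at larger amounts of compound and lower numbers for an effect already at smaller amounts.
Compound 2, `CCC(C)(C)Cc1c[nH]c(CCc2ccc(-n3ncnn3)cc2)n1`, gives 99 nM in this assay.
Compound 3, `CCC(C)(C)Cc1c[nH]c(CCc2ccc(-c3cnsc3)cc2)n1`, gives 119 nM in this assay.

All three share one core and differ only in the small ring attached to the six-membered carbon ring. Compound 3 stands level with compound 1 at the digits shown, and together these two carry the highest numbers of the three; the remaining gap is a 1.2-fold higher number from compound 2 to compound 3 (0.08 log units; within the scatter), while no change at the digits printed from compound 1 to compound 3 (within the scatter).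

Compound 4, `CCC(C)(C)Cc1c[nH]c(CCc2ccc(-n3cccn3)cc2)n1`, is the next member of this set. Relative to compound 3 the change is 1H-pyrazol-1-yl in place of 1,2-thiazol-4-yl on an aromatic carbon.

Every measured step in this set touches the same position and exchanges one small ring for another: a 1.2-fold lower number from compound 1 to compound 2 (0.08 log units; within the scatter), no change at the digits printed from compound 1 to compound 3 (within the scatter) and a 1.2-fold higher number from compound 2 to compound 3 (0.08 log units; within the scatter). None of them moved the number beyond the scatter. A further exchange of one five-membered ring for another at that position is therefore expected to leave the number in this assay essentially unchanged, so a 1.0-fold lower number from compound 3 to compound 4 (0.01 log units; within the scatter) is the expected step. Compound 4 is estimated at 115 nM, with a likely range from 60 nM to 230 nM.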

Compound 4, half-maximal effective concentration: 113 nM
Beside the measured number, compound 4's estimate is 1.0-fold (0.01 log units) above it; measured number inside the range.
By their numbers in this assay, from the lowest: compounds 2, 4, 1 and 3 (each within the scatter of the next).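

Exchanging the 1,2-thiazol-4-yl of compound 3 for the 1H-pyrazol-1-yl gives a 1.1-fold lower number from compound 3 to compound 4 (0.02 log units; within the scatter) in this assay and shows that a ring nitrogen can stand in place of the ring sulfur here with no measurable effect. The two groups have the same ring size and the same counts of hetero atoms, hydrogen-bond donors and hydrogen-bond acceptors, so this is a closer comparison than the earlier exchanges. The wider comparisons, a 1.1-fold higher number from compound 2 to compound 4 (0.06 log units; within the scatter) and a 1.1-fold lower number from compound 1 to compound 4 (0.02 log units; within the scatter) in the same assay, place compound 4 among the others, so all four groups at this position remain indistinguishable on this read-out.

Nothing available explains why these groups give such similar numbers.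

Going by these compounds, it remains open whether a carboxylic acid or a longer alkyl chain at this position, in place of these aromatic rings, would move the number beyond the scatter. On these data alone, it is also open whether these rings would stay level if another part of the shared core were changed.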